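Benzoyl ring substitution in the stilbene chalcone series

The source may report more compounds than this note shows. Statements on the series, on what has been measured and on what is new or still open speak of the compounds shown alone.

Measured in a functional assay on A549 cells (Homo sapiens) for antiproliferative activity, read by MTT assay, with a stated time of 48 h; a lower number here means a stronger inhibitor, a higher number a weaker inhibitor:
compound 1 `COc1ccc(/C=C/c2cc(OC)cc(OC)c2/C=C/C(=O)c2ccccc2)cc1` gives 3.9 ug/mL
compound 2 `COc1ccc(/C=C/c2cc(OC)cc(OC)c2/C=C/C(=O)c2cccc(Br)c2)cc1` gives 8.1 ug/mL
compound 3 `COc1ccc(/C=C/c2cc(OC)cc(OC)c2/C=C/C(=O)c2ccc(C(F)(F)F)cc2)cc1` gives 7.8 ug/mL

Compound 1, with the unsubstituted benzoyl, gives the lowest number of the three. The step of a 2.0-fold higher number from compound 1 to compound 3 (0.30 log units; within the scatter) stays within the scatter, whereas the step of a 2.1-fold higher number from compound 1 to compound 2 (0.32 log units; beyond the scatter) just passes beyond it. Between the two substituted analogues the step of a 1.0-fold lower number from compound 2 to compound 3 (0.02 log units; within the scatter) is flat.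

Compound 4 `COc1ccc(/C=C/c2cc(OC)cc(OC)c2/C=C/C(=O)c2ccc(C)c(C)c2)cc1` is the next member: 3,4-dimethylphenyl in place of phenyl on a carbonyl carbon. Both measured steps from compound 1 bear on this change, since each also places a substituent on the ring attached to the carbonyl carbon. Neither moved the number by much, and both moved it in the same direction, towards a higher number. The change to compound 4 puts two groups on that ring rather than one, but nothing here shows whether a second group adds to the effect or not. A step of about the same size as the two known ones, towards a higher number, is therefore expected in this assay for compound 4, with a wide margin around it.

Compound 4 is estimated at 6.5 ug/mL, range 3.5 ug/mL to 12 ug/mL, corresponding to an expected step of a 1.7-fold higher number from compound 1 to compound 4 (0.22 log units; within the scatter).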

Compound 4, half-maximal inhibitory concentration: 0.1 ug/mL
The estimate for compound 4 lay 65-fold (1.81 log units) above the measured number; measured number below the stated range.
By their numbers in this assay, from the lowest: compound 4; then compounds 1, 3 and 2 (each within the scatter of the next, the first and the last beyond it).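

In this assay, the ring on the carbonyl carbon turns out to be a position of high sensitivity: a 39-fold lower number from compound 1 to compound 4 (1.59 log units; beyond the scatter), whereas the bromo and trifluoromethyl replacements had only raised the number slightly. The gap to the two earlier substituted analogues is wider still, with a 78-fold lower number from compound 3 to compound 4 (1.89 log units; beyond the scatter) and an 81-fold lower number from compound 2 to compound 4 (1.91 log units; beyond the scatter), so substitution on this ring has no single direction: compound 2 and compound 3 sit on the higher side of compound 1, and compound 4 sits far on the lower side. No supporting data are available that would account for this reversal or tie it to any property of the 3,4-dimethylphenyl group.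

On these data alone, whether a single methyl group on that ring would give a low number, or whether both methyl groups are needed, remains open. As far as these compounds go, it is also open whether larger or different groups on the same ring, such as ethyl, methoxy or an amine, would keep the low number, and the large step currently rests on compound 4 alone in this one cell assay.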